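From a Methyl Triazole to a Methyl Pyrazole

The source may hold more compounds than are shown below. What is called first, only, known or untested is meant among the compounds shown, and "the series" means these compounds.

Compound 1 `c1ccc(-c2nc[nH]n2)c(NCC2=NCCN2)c1`: 5.01 nM
Compound 2 `Cn1ncnc1-c1ccccc1NCC1=NCCN1`: 39.8 nM
Compound 3 `CC(C)n1ncnc1-c1ccccc1NCC1=NCCN1`: < 100000 nM, a limit of the assay rather than a number

The three measured compounds share one core and differ only in the five-membered ring attached to it. In an in vitro functional assay on cells (Fibroblast) for agonist activity at Alpha-1B adrenergic receptor (Homo sapiens) (on this read-out lower numbers stand for an effect already at smaller amounts and higher numbers for an effect only at larger amounts of compound), compound 1 gives 5.01 nM. Compound 2 gives 39.8 nM in this assay, the highest of the two numbers read out, and the step of a 7.9-fold higher number from compound 1 to compound 2 (0.90 log units; beyond the scatter) is the only sized step shown. Compound 3 reaches only < 100000 nM, which is a limit of the assay and not a number. The step that the limit leaves unreadable from compound 2 to compound 3 therefore cannot be sized, as the limit of < 100000 nM in this assay, at which 1 of the 3 values shown sits, makes clear.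

Compound 4 `Cn1nccc1-c1ccccc1NCC1=NCCN1` has not yet been measured. It differs from compound 2 in one place: 1-methyl-1H-pyrazol-5-yl in place of 1-methyl-1H-1,2,4-triazol-5-yl on an aromatic carbon. Both measured steps change what sits on the nitrogen of the triazole, not the ring itself, so neither bears directly on this change, and no cause can be read from them. With a small group of the same size kept in place, a step of modest size is expected: a 1.3-fold higher number from compound 2 to compound 4 (0.10 log units; within the scatter). Compound 4 is therefore estimated at 50 nM, with a range from 10 nM to 250 nM.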

Compound 4, half-maximal effective concentration: < 100000 nM
Compound 4: only a limit was reported; the forecaster's own chance of this, stated with the estimate: 10%; the middle value does not contradict the limit.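

In this assay compound 4 gives < 100000 nM as a limit of the assay and not a number. Its steps from compound 1 and from compound 2 therefore cannot be read, because no size can be taken from such a result: the limit of < 100000 nM in this assay, at which 2 of the 4 values shown sit. The compounds shown leave open how the 1-methyl-1H-pyrazol-5-yl of compound 4 truly compares with the 1-methyl-1H-1,2,4-triazol-5-yl of compound 2.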